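The source may hold more compounds than are shown below. What is called first, only, known or untested is meant among the compounds shown, and "the series" means these compounds.

Measured compounds in an ADME assay on microsomes from liver (Rattus norvegicus) for metabolic stability; on this read-out higher numbers stand for a longer-lived compound and lower numbers for a shorter-lived compound:

Compound 1, `CC(C)(C)c1nc2c(C(=O)NCC3CCN(CC(O)CN4CCN(S(C)(=O)=O)CC4)CC3)cccc2[nH]1`, gives the limit > 1.5 h.
Compound 2, `CC(C)c1nc2c(C(=O)NCC3CCN(CCN4CCN(S(C)(=O)=O)CC4)CC3)cccc2[nH]1`, gives the limit > 1.5 h.
Compound 3, `CC(=O)N1CCN(CCN2CCC(CNC(=O)c3cccc4[nH]c(C(C)C)nc34)CC2)CC1`, gives the limit > 1.5 h.

Compound 3 therefore stands at the limit of > 1.5 h in this assay, at which 3 of the 3 values shown sit, and its value is a limit of this assay rather than a number. Going by the values given here, the one step that bears on it, a step that the two limits leave unreadable from compound 2 to compound 3, is likewise left unreadable by the two limits, so no size can be read from it. Compound 4 is `CC(=O)N1CCC(CN2CCC(CNC(=O)c3cccc4[nH]c(C(C)C)nc34)CC2)CC1`; it differs from compound 3 by 1-acetylpiperidin-4-yl in place of (4-acetylpiperazin-1-yl)methyl on a saturated chain carbon bound to an amine nitrogen in a ring. With every shown value resting on the same limit, no step beyond the scatter can be expected from this change, and compound 4 is estimated at 2.5 h, in the range 1 h to 6 h, an expected step that the limit leaves unreadable from compound 3 to compound 4.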

Compound 4, half-life: > 1.5 h
Compound 4 was reported as a limit; the forecaster's own chance of this, stated with the estimate: 70%; the middle value does not contradict the limit.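

Compound 4 also rests on a limit, so the steps to it from compound 2 and compound 3 cannot be read: the limit of > 1.5 h in this assay, at which 4 of the 4 values shown sit.

The compounds shown leave open whether their half-lives in this assay differ at all.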